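The compounds below may be only part of what the source reports. "The series", "measured", "known", "first", "only" and "open" are said of these compounds alone.

Measured compounds:
compound 1, `Cc1nc(Nc2ccccc2)sc1C(=O)/C=C/c1ccc(Cl)cc1`: > 25000 nM
compound 2, `Cc1cccc(Nc2nc(C)c(C(=O)/C=C/c3ccccc3)s2)c1`: 11700 nM

Among the compounds with values here, in a functional assay on PC-3 cells (Homo sapiens) for cytotoxicity, read by MTT assay (on this read-out higher numbers stand for weaker inhibition and lower numbers for stronger inhibition), compound 2 gives 11700 nM, the only outright number in the set. For compound 1 the read-out in this assay stops at > 25000 nM, which is a limit of the assay and not a number; this is the limit of > 25000 nM in this assay, at which 1 of the 2 values shown sits. Within the data shown here, with one number and one limit, no step between measured compounds that differ in one place can be drawn, and no ordering of the two is attempted beyond what the values themselves show.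

The step to compound 3, `Cc1cccc(Nc2nc(C)c(C(=O)/C=C/c3ccc(Cl)cc3)s2)c1`, is chloro in place of hydrogen on an aromatic carbon, para to a large group. Among the measured compounds shown here, no measured pair isolates this change, so the expectation for compound 3 in this assay rests on compound 2 alone: a small step, possibly toward weaker inhibition, but nothing that should clearly exceed the usual scatter. Compound 3 is therefore expected to give 15000 nM in this assay, within 6000 nM to 40000 nM, meaning an estimated step of a 1.3-fold higher number from compound 2 to compound 3 (0.11 log units; within the scatter).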

Compound 3, half-maximal inhibitory concentration: > 25000 nM
Compound 3: only a limit was reported; the forecaster's own chance of this, stated with the estimate: 30%; middle value at least 1.6-fold (0.22 log units) away from the limit.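

In this assay, within the data shown here, 4-chlorophenyl in place of phenyl is the first change whose size can be judged, and chloro in place of hydrogen, para to a large group, gives an at least 2.1-fold higher number from compound 2 to compound 3 (0.32 log units; beyond the scatter), so the hydrogen-bearing phenyl of the shared core is not interchangeable with its chloro counterpart on this read-out. Compound 3 gives > 25000 nM, which is a limit of the assay and not a number. The step therefore has a lower bound only, its full size stays hidden, and compound 2 remains the only compound in the set with an outright number: the limit of > 25000 nM in this assay, at which 2 of the 3 values shown sit.

On these data alone, the step between compound 1 and compound 3 cannot be read, since both values are limits, so what the methyl group adds on the other aromatic ring stays unknown on this read-out. Also open, as far as these compounds go, is whether fluoro or methoxy in place of the chloro, or an amine or a carboxylic acid at that same place, would give a value that can be read as a number rather than a limit.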